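This account rests on a few compounds, and the source may have more. Where it says the series, first, only, none or still open, it means among the compounds named here.

Compound 1 `CSc1ccnc(Nc2ccc(Cl)c(OCC=C(C)C)c2)n1` gives 2800 nM in a functional assay on MT2 cells (Homo sapiens) for cytotoxicity, read by MTT assay; on this read-out higher numbers stand for lower toxicity in this test and lower numbers for higher toxicity in this test; compound 2 `COc1ccnc(Nc2ccc(Cl)c(OCC=C(C)C)c2)n1` gives 9000 nM.

Compound 2 holds the highest number of the two, with compound 1 the nearest, the step being a 3.2-fold higher number from compound 1 to compound 2 (0.51 log units; beyond the scatter). Compound 3 `CC(C)=CCOc1cc(Nc2nccc(N)n2)ccc1Cl` is not yet measured and differs from compound 2 in one place: amino in place of methoxy on an aromatic carbon. Among the measured compounds shown here, the only measured step that touches this position is the one from compound 1 to compound 2, where methoxy in place of methylsulfanyl on an aromatic carbon gave a 3.2-fold higher number from compound 1 to compound 2 (0.51 log units; beyond the scatter). That single step shows the position can move the read-out, but it does not involve amino, so the direction for compound 3 is open. Compound 3 is therefore expected to stay near compound 2, with an expected step of no change at the digits printed from compound 2 to compound 3 (within the scatter). The estimate for compound 3 is 9000 nM, with a range from 3500 nM to 25000 nM.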

Compound 3, half-maximal cytotoxic concentration: 500 nM
Beside the measured number, compound 3's estimate is 18-fold (1.26 log units) above it; the measured number lies below the stated range.
By their numbers in this assay, from the lowest: compound 3; then compound 1; then compound 2.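

Amino in place of methoxy gives an 18-fold lower number from compound 2 to compound 3 (1.26 log units; beyond the scatter) in this assay and moves the read-out in the opposite direction to the earlier step, so this position can both raise and lower the number. Amino in place of methylsulfanyl gives a 5.6-fold lower number from compound 1 to compound 3 (0.75 log units; beyond the scatter) as well, which places compound 3 lowest of the three and shows that the earlier pair did not span the range at this position. Nothing here accounts for the shift toward higher toxicity in this test.

The compounds shown leave open whether methylamino or dimethylamino at this position would stay near amino or move toward methoxy. They also leave open whether a hydroxyl group, which like amino carries a hydrogen on its heteroatom, would give a similarly low number.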